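A few compounds are considered here, and "the series" means these few. Any claim that something is new, unique, unknown or untested is made for them only; others in the source may bear on it.

Measured so far in a functional assay on CCRF-CEM cells for antagonist activity at C-X-C chemokine receptor type 4 (Homo sapiens), read by calcium flux, with stated times of 25 min and 90 s; on this read-out lower numbers stand for stronger inhibition and higher numbers for weaker inhibition:
- compound 1, `CCCN(C[C@H]1Cc2c(cccc2N2CCNCC2)CN1)[C@H]1CCCc2cccnc21`, gives 32.2 nM
- compound 2, `CN(C[C@H]1Cc2c(cccc2N2C[C@@H]3C[C@H]2CN3)CN1)[C@H]1CCCc2cccnc21`, gives 146 nM
- compound 3, `CN(C[C@@H]1Cc2c(cccc2N2CCNCC2)CN1)[C@H]1CCCc2cccnc21`, gives 313 nM

Compound 3 stands at the highest of the three numbers. Its nearest neighbour is compound 2, whose number is lower by a margin beyond the scatter; compound 1 lies furthest away, with a number lower by a margin well beyond the scatter. Within the data shown here, no two of the measured compounds differ in a single place, so no measured step is available for calibration.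

The next compound, compound 4, is `CN(C[C@H]1Cc2c(cccc2N2CCNCC2)CN1)[C@H]1CCCc2cccnc21`. It is compared with compound 3 as follows: the two compounds have the same atoms and bonds and differ only in configuration as drawn: 1 of 2 stereo elements differ; a stereocentre at a saturated ring carbon is drawn S in compound 3 and R in compound 4.

With no measured step of this kind in the series, the expectation rests on the spread of the numbers shown and on the fact that the change is purely one of configuration. Such inversions commonly move the read-out by a clear margin, and the direction of the estimate is toward a lower number. Compound 4 is estimated to give 60 nM, with a range from 15 nM to 250 nM, which is an expected step of a 5.2-fold lower number from compound 3 to compound 4 (0.72 log units; beyond the scatter).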

Compound 4, half-maximal inhibitory concentration: 6.08 nM
Beside the measured number, compound 4's estimate is 9.9-fold (0.99 log units) above it; measured number below the stated range.
By their numbers in this assay, from the lowest: compound 4; then compound 1; then compound 2; then compound 3.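

In this assay, inverting the saturated ring carbon from S to R gives a 51-fold lower number from compound 3 to compound 4 (1.71 log units; beyond the scatter), and the whole of this step belongs to that stereocentre, on the following ground: the fact that compounds 3 and 4 differ only in the configuration as drawn. The other two steps are smaller: the group of 6 heavy atoms with one six-membered non-aromatic ring, in place of the group of 7 heavy atoms with 2 five-membered non-aromatic rings, gives a 24-fold lower number from compound 2 to compound 4 (1.38 log units; beyond the scatter). Hydrogen in place of ethyl on the saturated chain carbon bound to the amine nitrogen gives the smallest step, a 5.3-fold lower number from compound 1 to compound 4 (0.72 log units; beyond the scatter).

Open, from the compounds shown here alone, is whether the preference for R at this stereocentre also holds with the longer chain of compound 1. Also open, going by these compounds, is how a hydroxyl or a carboxylic acid on that chain would read out.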